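Hydroxamate series: aryl ketone swap at the distal end

This account rests on a few compounds, and the source may have more. Where it says the series, first, only, none or still open, it means among the compounds named here.

Among the compounds with values here, compound 2 `Cn1cc(/C=C/C(=O)c2ccccc2Cl)cc1/C=C/C(=O)NO` is the weaker of the two measured members. Within the data shown here, in an assay on isolated protein for inhibition of histone deacetylase HD1B (Zea mays) (a higher number here means a weaker inhibitor, a lower number a stronger inhibitor), compound 2 gives 1600 nM, the highest of the two numbers so far, while its nearest neighbour compound 1 `Cn1cc(/C=C/C(=O)c2ccccc2)cc1/C=C/C(=O)NO` gives 260 nM. Among the measured compounds shown here, the one measured step, a 6.2-fold higher number from compound 1 to compound 2 (0.79 log units; beyond the scatter), shows that adding chloro on the aromatic carbon of the benzoyl group weakened inhibition beyond the scatter.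

Compound 3 `Cn1cc(/C=C/C(=O)c2ccco2)cc1/C=C/C(=O)NO` differs from compound 2 by furan-2-yl in place of 2-chlorophenyl on a carbonyl carbon. For the measured compounds named here, this change undoes the chloro addition of the measured step and at the same time exchanges the six-membered carbon ring for a five-membered ring with one oxygen; the second part has no counterpart among the measured compounds. Going by the values given here, the reverse of the step from compound 1 to compound 2 is the only guide, so the number is expected to fall. The estimated step of a 4.0-fold lower number from compound 2 to compound 3 (0.60 log units; beyond the scatter) is expected to be somewhat smaller than that step. On these data alone, the ring exchange is untested, and this leaves the estimate uncertain. Compound 3 is therefore estimated to give 400 nM in this assay, with a range from 150 nM to 1200 nM.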

Compound 3, half-maximal inhibitory concentration: 19700 nM
Beside the measured number, compound 3's estimate is 49-fold (1.69 log units) below it; measured number above the stated range.
By their numbers in this assay, from the lowest: compound 1; then compound 2; then compound 3.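

At this place on a carbonyl carbon, the ring decides the result: with furan-2-yl in place of 2-chlorophenyl, a 12-fold higher number from compound 2 to compound 3 (1.09 log units; beyond the scatter) in this assay, so losing the chloro does not return the series towards compound 1. With furan-2-yl in place of phenyl, a 76-fold higher number from compound 1 to compound 3 (1.88 log units; beyond the scatter) marks a far larger loss than the one seen with chloro on the phenyl ring, a 6.2-fold higher number from compound 1 to compound 2 (0.79 log units; beyond the scatter) being the smaller step, and this makes compound 3 the weakest of the three and leaves compound 1 the strongest. Within the data shown here, the six-membered carbon ring, with or without chloro, thus gives a lower number here than the five-membered ring with one oxygen, and nothing measured so far bears on the reason for this.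

These compounds cannot separate ring size from the ring oxygen, and thiophen-2-yl or pyridin-2-yl on the same carbonyl carbon would be the comparisons that address this. Also open, on these data alone, is whether a non-aromatic ring such as cyclohexyl, or a methoxy group or fluoro group on the phenyl ring in place of chloro, would keep the number near that of compound 1.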